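Butoxy for fluoro on the shared core

This account rests on a few compounds, and the source may have more. Where it says the series, first, only, none or still open, it means among the compounds named here.

Of the compounds shown here, two of one core have been measured so far. Compound 1, `CCCCOc1ccc([C@@H]2CC[C@@H](NC)c3ccccc32)cc1`, gives in a functional assay on Hypothalamus for inhibition of Norepinephrine transporter (Rattus norvegicus) (a lower number here means a stronger inhibitor, a higher number a weaker inhibitor), a value of 1150 nM. Compound 2, `CN[C@H]1CC[C@@H](c2ccc(F)cc2)c2ccccc21`, gives in this assay a value of 2300 nM. Compound 2 thus carries the higher of the two numbers, but the gap to compound 1 lies within the scatter, so nothing can be said about an order between them.

The untested compound 3, `CCCCOc1ccc([C@@H]2CC[C@H](NC)c3ccccc32)cc1`, differs from compound 2 by a single replacement: butoxy in place of fluoro on an aromatic carbon. The group that enters is the same butoxy that compound 1 carries at the same kind of position, and compound 1 sits within the scatter of compound 2.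

Because compound 1 with butoxy gives 1150 nM in this assay, the expected step of a 1.8-fold lower number from compound 2 to compound 3 (0.25 log units; within the scatter) is at most a small move toward a lower number, and may be none beyond the scatter. Compound 3 is therefore expected to give about 1300 nM in this assay, with a range from 350 nM to 5000 nM.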

Compound 3, half-maximal inhibitory concentration: 940 nM
Compound 3: the middle estimate sits 1.4-fold (0.14 log units) above what was measured; the measured number falls inside the stated range.
By their numbers in this assay, from the lowest: compounds 3, 1 and 2 (each within the scatter of the next, the first and the last beyond it).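

In this assay, butoxy in place of fluoro on an aromatic carbon, para to a large group, gives a 2.4-fold lower number from compound 2 to compound 3 (0.39 log units; beyond the scatter), a modest step. The earlier pair, compounds 1 and 2, lay within the scatter of each other and so could not show this; the new pair shows that the five heavy atoms of butoxy in place of the single fluorine are tolerated here, with a small move toward a lower number rather than a loss. The comparison with the other butoxy compound gives a 1.2-fold lower number from compound 1 to compound 3 (0.09 log units; within the scatter), so the change at a stereocentre on a saturated ring carbon, drawn R in compound 1 and S in compound 3, leaves no difference that can be read, and that comparison isolates this one stereocentre: the fact that compounds 1 and 3 differ only in the configuration as drawn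

As far as these compounds go, it remains open whether a methoxy group, a longer hexyloxy chain or an amine on the same aromatic carbon would move the number further, and so whether the step follows the length of the chain. Also open, from the compounds shown here alone, is whether fluoro to butoxy would give a step of like size in the other configuration at that stereocentre.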